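This account rests on a few compounds, and the source may have more. Where it says the series, first, only, none or still open, it means among the compounds named here.

Compound 1 `CC[C@@H]1C[C@H](CC)CN(CCCNC(=O)C2CCN(Cc3nc(-c4ccccc4C)oc3C)CC2)C1`: in a physicochemical assay for permeability, using PAMPA (a lower number here means that the compound crosses the layer more slowly, a higher number that the compound crosses the layer faster), compound 1 gives 1270 10^-6 cm/s.
Compound 2 `Cc1ccccc1-c1nc(CN2CCC(C(=O)NCCCN3CC(C)(C)CC(C)(C)C3)CC2)c(C)o1`: for compound 2 this assay reports only a limit, > 1390 10^-6 cm/s.
Compound 3 `Cc1ccccc1-c1nc(CN2CCC(C(=O)NCCCN3CCC(C)(C)CC3)CC2)c(C)o1`: in this assay compound 3 gives 241 10^-6 cm/s.

Of the two plain numbers, compound 3 holds the lower one; its nearest neighbour is compound 1, and the step between them reads a 5.3-fold lower number from compound 1 to compound 3 (0.72 log units; beyond the scatter). Compound 4 `Cc1ccccc1-c1nc(CN2CCC(C(=O)NCCCN3[C@H](C)CCC[C@@H]3C)CC2)c(C)o1` has not yet been measured. It differs from compound 3 in one place: 2,6-dimethylpiperidin-1-yl in place of 4,4-dimethylpiperidin-1-yl on a saturated chain carbon, three bonds along the chain from an amide-type nitrogen. Within the data shown here, two measured steps touch the same place and are the only guide. One is a 5.3-fold lower number from compound 1 to compound 3 (0.72 log units; beyond the scatter); the other, which ends at a limit, is an at least 5.7-fold lower number from compound 2 to compound 3 (0.76 log units; beyond the scatter) (the limit of > 1390 10^-6 cm/s in this assay, at which 1 of the 3 values shown sits). Both swaps of the ring at this position moved the number well beyond the scatter, and in both the 4,4-dimethylpiperidin-1-yl ring of compound 3 gave the lower figure. With only these two steps, and neither involving 2,6-dimethylpiperidin-1-yl, the direction is uncertain, but the rise is expected to be more likely than a further fall, and the step is estimated as a 2.3-fold higher number from compound 3 to compound 4 (0.36 log units; beyond the scatter). Compound 4 is therefore estimated at 550 10^-6 cm/s, with a likely range from 170 10^-6 cm/s to 1390 10^-6 cm/s.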

Compound 4, apparent permeability: 55.4 10^-6 cm/s
Compound 4: the middle estimate sits 9.9-fold (1.00 log units) above what was measured; the measured number lies below the stated range.
By their numbers in this assay, from the lowest: compound 4; then compound 3; then compound 1. At a limit, above all of these: compound 2.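

In this assay, among these compounds, the earlier steps at this position all swapped rings that could differ in their atoms, but compound 3 and compound 4 hold the same atoms, joined differently, and the number still moves: a 4.4-fold lower number from compound 3 to compound 4 (0.64 log units; beyond the scatter). Rearranging the two methyl groups on the piperidine is therefore enough on its own to shift the reading beyond the scatter, and 2,6-dimethylpiperidin-1-yl now gives the lowest number of the series, with a 23-fold lower number from compound 1 to compound 4 (1.36 log units; beyond the scatter). A further step, an at least 25-fold lower number from compound 2 to compound 4 (1.39 log units; beyond the scatter), starts from a limit and not from a plain number: the limit of > 1390 10^-6 cm/s in this assay, at which 1 of the 4 values shown sits.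

The compounds shown do not tell whether this low reading belongs to the 2,6-dimethylpiperidin-1-yl group in general or to the one arrangement of its two defined stereocentres found in compound 4. From the compounds shown here alone, how a plain unsubstituted piperidine, a morpholine or a pyrrolidine would read at this spot on the same three-bond chain also stays open, as does the effect of a longer chain.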